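The source may report more compounds than this note shows. Statements on the series, on what has been measured and on what is new or still open speak of the compounds shown alone.

Of the compounds shown here, three have been tested so far in an assay on WI 38 cells for displacement of a labelled ligand from B1 bradykinin receptor (Homo sapiens); a higher number here means a weaker inhibitor, a lower number a stronger inhibitor. Compound 1 `COc1cc(CN(CC(=O)NCc2ccccc2Cl)S(=O)(=O)c2ccc(CN(C)C)cc2)ccc1OCC(C)C` gives 93 nM, and compound 2 `CC(C)COc1ccc(CN(CC(=O)NCc2ccccc2Cl)S(=O)(=O)c2ccc(CN3CCN(C)CC3)cc2)cc1` gives 113 nM. Compound 3 `O=C(O)CCNC(=O)CN(CCOc1cccc(Cl)c1)S(=O)(=O)c1ccc(Cl)cc1Cl` gives 1090 nM, the highest of the three numbers, and its gap to both compound 2 and compound 1 lies beyond the usual scatter. Compound 4 `O=C(O)CCNC(=O)CN(CCOc1ccc2c(c1)CCC2)S(=O)(=O)c1ccc(Cl)cc1Cl` has not yet been measured. It differs from compound 3 in one place: 2,3-dihydro-1H-inden-5-yl in place of 3-chlorophenyl on an oxygen on a saturated carbon. For the measured compounds named here, no two measured compounds differ in a single place, so there is no directly comparable step to lean on. Exchanging one ring group for another at this position is expected to move the number only a little, within or just beyond the scatter. Compound 4 is therefore estimated at 800 nM in this assay, between 250 nM and 2500 nM, an expected step of a 1.4-fold lower number from compound 3 to compound 4 (0.13 log units; within the scatter).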

Compound 4, inhibition constant: 410 nM
Compound 4: middle estimate off by 2.0-fold (0.29 log units), on the high side, and the stated range covers the measured number.
By their numbers in this assay, from the lowest: compounds 1 and 2 (each within the scatter of the next); then compound 4; then compound 3.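

In this assay the exchange of 3-chlorophenyl for 2,3-dihydro-1H-inden-5-yl on the oxygen gives a 2.7-fold lower number from compound 3 to compound 4 (0.42 log units; beyond the scatter) and so shows that this position responds to the ring group it carries. In this pair the chlorine can be given up without loss, and a group of all carbon with a second, non-aromatic ring is accepted. Nothing at hand explains why the number falls.

As far as these compounds go, it remains open whether the change comes from losing the chlorine or from gaining the five-membered ring. A plain phenyl or a 3-methylphenyl group at this position would help separate the two.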